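Chloro to fluoro swap on two related cores

The compounds below may be only part of what the source reports. "The series", "measured", "known", "first", "only" and "open" are said of these compounds alone.

Three compounds have been measured in a functional assay on SW1573 cells (Homo sapiens) for inhibition, read by sulforhodamine B assay, with a stated time of 48 h; on this read-out lower numbers stand for stronger inhibition of growth and higher numbers for weaker inhibition of growth:
Compound 1 `CC(=O)OC/C(=C\c1ccc(Cl)cc1)C(=O)c1ccccc1` gives 2600 nM.
Compound 2 `CC(=O)OC/C(=C\c1ccc(F)cc1)C(=O)c1ccccc1` gives 4200 nM.
Compound 3 `C=C(C/C(=C\c1ccc(Cl)cc1)C(=O)c1ccccc1)C(=O)c1ccccc1` gives 6100 nM.

Compound 1 and compound 2 share one core and differ by fluoro in place of chloro on an aromatic carbon; this gave a 1.6-fold higher number from compound 1 to compound 2 (0.21 log units; within the scatter). Compound 3 carries a different core; the difference between the two cores is not broken down here. Compound 4 `C=C(C/C(=C\c1ccc(F)cc1)C(=O)c1ccccc1)C(=O)c1ccccc1` has not yet been measured. Among the measured compounds shown here, it differs from compound 3 by fluoro in place of chloro on an aromatic carbon, the same change as the one between compound 1 and compound 2, made at the same place. The step from compound 3 to compound 4 is expected to be a 1.4-fold higher number from compound 3 to compound 4 (0.14 log units; within the scatter), resting on the earlier step of a 1.6-fold higher number from compound 1 to compound 2 (0.21 log units; within the scatter), which itself lies within the scatter. Compound 4 is therefore estimated at 8500 nM, with a likely range from 4000 nM to 18000 nM.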

Compound 4, concentration for 50% growth inhibition: 3500 nM
Compound 4: middle estimate off by 2.4-fold (0.39 log units), on the high side; the whole stated range lies above it.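

In this assay putting fluoro in place of chloro on the core of compound 3 gave a 1.7-fold lower number from compound 3 to compound 4 (0.24 log units; within the scatter) and did not repeat the earlier step. The two steps run in opposite directions, and the gap between them lies beyond the scatter, so on these two pairs the size and direction of the change cannot simply be carried from one core to the other: the same change on two cores in this assay, a 1.6-fold higher number (0.21 log units; within the scatter) from compound 1 to compound 2 and a 1.7-fold lower number (0.24 log units; within the scatter) from compound 3 to compound 4, 2.8-fold (0.45 log units) apart, beyond the scatter of two such steps. Each step taken alone lies within the scatter, and two pairs cannot show why the cores differ or how the change would behave on any further core.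

Still open, from the compounds shown here alone, is whether bromo, methoxy or an amine on the same aromatic carbon would follow the pattern of either core.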